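The compounds below may be only part of what the source reports. "The series", "measured", "known", "first", "only" and "open" are said of these compounds alone.

Among the compounds with values here, in an ADME assay on brain (Mus musculus) for protein binding, using equilibrium dialysis (on this read-out higher numbers stand for a larger free fraction and lower numbers for a smaller free fraction), compound 3 (`O=C(Nc1ccc(F)cn1)c1cc(Cl)cc(Oc2cncc(F)c2)c1`) gives 0.007, the lowest of the three numbers so far. Compound 1 (`O=C(Nc1cccc(Cl)n1)c1cc(Cl)cc(Oc2cncnc2)c1`) gives 0.019 and compound 2 (`Cc1cccc(NC(=O)c2cc(Cl)cc(Oc3cncnc3)c2)n1`) gives 0.052. Compound 4 (`Cc1cccc(NC(=O)c2cc(Cl)cc(Oc3cncc(F)c3)c2)n1`) departs from compound 3 in one place: 6-methylpyridin-2-yl in place of 5-fluoropyridin-2-yl on an amide-type nitrogen. Thus 6-methylpyridin-2-yl stands in place of 5-fluoropyridin-2-yl on an amide-type nitrogen. Within the data shown here, the only measured step that bears on this is a 2.7-fold higher number from compound 1 to compound 2 (0.44 log units; beyond the scatter), a modest change beyond the scatter, where methyl replaces chloro on an aromatic carbon. It is a related change rather than the same one, and it was measured on a different remainder of the molecule. On that evidence, a rise of similar size is expected, an estimated 2.7-fold higher number from compound 3 to compound 4 (0.43 log units; beyond the scatter). The estimate for compound 4 is 0.019, with an expected range of 0.009 to 0.04.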

Compound 4, unbound fraction: 0.003
Beside the measured number, compound 4's estimate is 6.3-fold (0.80 log units) above it, outside the stated range (below it).
By their numbers in this assay, from the lowest: compound 4; then compound 3; then compound 1; then compound 2.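

In this assay, 6-methylpyridin-2-yl in place of 5-fluoropyridin-2-yl on an amide-type nitrogen gives a 2.3-fold lower number from compound 3 to compound 4 (0.37 log units; beyond the scatter), so a methyl-bearing group entering here does not bring the rise seen with a 2.7-fold higher number from compound 1 to compound 2 (0.44 log units; beyond the scatter). The direction of a change at this nitrogen therefore depends on which group leaves and on the remainder of the molecule. The other new step, 5-fluoropyridin-3-yl in place of pyrimidin-5-yl on an oxygen on an aromatic ring, is large, with a 17-fold lower number from compound 2 to compound 4 (1.24 log units; beyond the scatter).

Nothing shown gives a reason for either step. Still open, as far as these compounds go, is how the free fraction would read with an amine or a carboxylic acid on the pyridine at the amide-type nitrogen.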